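From thiophen-3-yl to 2-chlorophenyl on the shared core

The source may hold more compounds than are shown below. What is called first, only, known or untested is meant among the compounds shown, and "the series" means these compounds.

Measured in a functional assay on HCT-116 cells (Homo sapiens) for antiproliferative activity, with a stated time of 72 h; a higher number here means a weaker inhibitor, a lower number a stronger inhibitor:
- compound 1 `Nc1ncnn2c([C@@H]3O[C@H](CO)[C@@H](O)[C@H]3O)cc(C#CC3CC3)c12`: 50 nM
- compound 2 `Nc1ncnn2c([C@@H]3O[C@H](CO)[C@@H](O)[C@H]3O)cc(-c3ccc(F)cc3)c12`: 42500 nM
- compound 3 `Nc1ncnn2c([C@@H]3O[C@H](CO)[C@@H](O)[C@H]3O)cc(-c3ccsc3)c12`: 45200 nM

Compound 3 sits at the weak end of this small set alongside compound 2, since a 1.1-fold higher number from compound 2 to compound 3 (0.03 log units; within the scatter) stays within the scatter. It lies far from compound 1, with a 900-fold higher number from compound 1 to compound 3 (2.96 log units; beyond the scatter).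

Compound 4 `Nc1ncnn2c([C@@H]3O[C@H](CO)[C@@H](O)[C@H]3O)cc(-c3ccccc3Cl)c12` differs from compound 3 at one place: 2-chlorophenyl in place of thiophen-3-yl on an aromatic carbon. In words, 2-chlorophenyl stands in place of thiophen-3-yl on an aromatic carbon.

The large steps of an 850-fold higher number from compound 1 to compound 2 (2.93 log units; beyond the scatter) and a 900-fold higher number from compound 1 to compound 3 (2.96 log units; beyond the scatter) both involve loss of the 2-cyclopropylethynyl group, which compound 3 already lacks, so they do not predict this change. The nearest guide is the exchange of one aromatic ring group for another in compound 3, where a 1.1-fold higher number from compound 2 to compound 3 (0.03 log units; within the scatter) stayed within the scatter. Among the compounds with values here, no measured compound carries 2-chlorophenyl, so the uncertainty is wide.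

In this assay no step beyond the scatter is expected, and the estimated change is a 1.3-fold lower number from compound 3 to compound 4 (0.11 log units; within the scatter). The estimate for compound 4 is 35000 nM, with an expected range from 10000 nM to 90000 nM.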

Compound 4, half-maximal inhibitory concentration: > 100000 nM
Compound 4: no number, only a limit (the forecaster's own chance of this, stated with the estimate: 20%); at least 2.8-fold (0.45 log units) between middle value and limit.
By their numbers in this assay, from the lowest: compound 1; then compounds 2 and 3 (each within the scatter of the next). At a limit, above all of these: compound 4.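

In this assay compound 4 gives no number but a limit: the limit of > 100000 nM in this assay, at which 1 of the 4 values shown sits.

The exchange of 4-fluorophenyl for thiophen-3-yl had stayed within the scatter, but 2-chlorophenyl at this position gives a step beyond it, with an at least 2.2-fold higher number from compound 3 to compound 4 (0.34 log units; beyond the scatter) and an at least 2.3-fold higher number from compound 2 to compound 4 (0.37 log units; beyond the scatter) as the two comparisons, so the aromatic groups shown here are not all equivalent in this assay. Set against 2-cyclopropylethynyl, the change is large, with an at least 2000-fold higher number from compound 1 to compound 4 (3.30 log units; beyond the scatter) placing compound 4 as far from compound 1 as the limit allows to be read, and compounds 2, 3 and 4 all stay far from compound 1.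

Going by these compounds, how a plain phenyl group or a simple propynyl chain would behave at this position remains open. Also open, on these data alone, is whether the strength of compound 1 rests on the triple bond, the cyclopropyl ring or the two together.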